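Compound 2 to compound 3: methoxy to chloro

The source may report more compounds than this note shows. Statements on the series, on what has been measured and on what is new or still open speak of the compounds shown alone.

In a physicochemical assay for solubility, with a stated time of 3 days, at pH 2 (on this read-out lower numbers stand for lower solubility and higher numbers for higher solubility), compound 1 `Cc1ccc(CN2CCCCC2CCOc2ccc(-c3nc4cc(C(N)=O)ccc4[nH]3)cc2)cc1` gives > 400000 nM as a limit of the assay. Compound 2 `COc1ccc(CN2CCCCC2CCOc2ccc(-c3nc4cc(C(N)=O)ccc4[nH]3)cc2)cc1` gives > 400000 nM in this assay and this too is a limit, so compound 2 has no exact number. Compound 3 `NC(=O)c1ccc2[nH]c(-c3ccc(OCCC4CCCCN4Cc4ccc(Cl)cc4)cc3)nc2c1` differs from compound 2 by chloro in place of methoxy on an aromatic carbon and the change reads chloro in place of methoxy on an aromatic carbon, 4-methoxybenzyl to 4-chlorobenzyl. Within the data shown here, the one measured step bearing on it is a step that the two limits leave unreadable from compound 1 to compound 2 and it offers no size to carry over. The remaining guide is the limit of > 400000 nM in this assay, at which 2 of the 2 values shown sit, and no step beyond the scatter is expected. The expected change is a number no higher from compound 2 to compound 3 (the limit leaves the size open) in this assay with no direction assigned. For compound 3 the estimate is 400000 nM with an expected range of 200000 nM to 600000 nM and a report as a limit is the likeliest outcome.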

Compound 3, solubility: > 400000 nM
Compound 3: no number, only a limit (the forecaster's own chance of this, stated with the estimate: 75%); the middle value lies on the limit itself.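

In this assay compound 3 gives > 400000 nM, which is a limit and not a number. The steps among compound 1, compound 2 and compound 3 therefore cannot be read: the limit of > 400000 nM in this assay, at which 3 of the 3 values shown sit.

From the compounds shown here alone, whether methyl, methoxy and chloro differ at all in this assay stays open.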